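The source may report more compounds than this note shows. Statements on the series, on what has been measured and on what is new or still open speak of the compounds shown alone.

In a functional assay on the whole organism with Scenedesmus acutus as the target, with a stated time of 20 h (on this read-out higher numbers stand for weaker inhibition and lower numbers for stronger inhibition), compound 1 `CC(Cl)/C=C/C(=O)N(Cc1ccc(C#N)cc1)CC(C)C` gives 1550 nM and compound 2 `CC(Cl)/C=C/C(=O)N(Cc1ccc(C(F)(F)F)cc1)CC(C)C` gives 661 nM as the lower of the two numbers, which here means the stronger inhibition. Among the measured compounds shown here, the one step measured so far is a 2.3-fold lower number from compound 1 to compound 2 (0.37 log units; beyond the scatter) and it is modest, though beyond the scatter. Compound 3 `CC(Cl)/C=C/C(=O)N(Cc1ccc(Cl)cc1)CC(C)C` is still unmeasured. It keeps the shared core and differs from compound 2 only on that same aromatic carbon: chloro in place of trifluoromethyl on an aromatic carbon in a single swap, chloro in place of trifluoromethyl on an aromatic carbon. For the measured compounds named here, only the step between compound 1 and compound 2 bears on this swap, and it offers a sense of scale rather than a rule, since no chloro compound has been measured here. It suggests that a swap at this place moves the number only modestly. A small step is therefore expected, leaning towards a higher number, and it may well stay within the scatter. The expected change is a 1.2-fold higher number from compound 2 to compound 3 (0.08 log units; within the scatter) in size and direction. Compound 3 is expected to read 800 nM within an estimated range from 350 nM to 1800 nM when it is measured.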

Compound 3, half-maximal inhibitory concentration: 550 nM
For compound 3 the middle estimate is 1.5-fold (0.16 log units) above the measured one; the range from low to high includes it.
By their numbers in this assay, from the lowest: compounds 3 and 2 (each within the scatter of the next); then compound 1.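

In this assay, replacing trifluoromethyl with chloro on this aromatic carbon, para to a large group, gives a 1.2-fold lower number from compound 2 to compound 3 (0.08 log units; within the scatter), so the two groups cannot be told apart here even though one has 4 heavy atoms and the other has 1. The new comparison with the nitrile compound gives a 2.8-fold lower number from compound 1 to compound 3 (0.45 log units; beyond the scatter), which is modest but beyond the scatter and points the same way as a 2.3-fold lower number from compound 1 to compound 2 (0.37 log units; beyond the scatter), so among these three compounds the nitrile-bearing compound 1 is the weakest inhibitor, while compound 2 and compound 3 read alike. No measurement is available that explains why chloro and trifluoromethyl read alike here or why the nitrile compound stands apart.

With only three groups shown at this one position, it remains open how an amine, a methoxy group, a carboxylic acid or a plain hydrogen would read there. Going by these compounds, it is also open whether chloro and trifluoromethyl would still read alike on a different carbon of the same ring, or with another chain in place of the one on the shared core.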